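A few compounds are considered here, and "the series" means these few. Any claim that something is new, unique, unknown or untested is made for them only; others in the source may bear on it.

Measured compounds:
- compound 1, `O=C(CSc1nnc(-c2ccncc2)o1)N/N=C/c1ccc(Br)cc1`: 18600 nM
- compound 2, `O=C(CSc1nnc(-c2ccncc2)o1)N/N=C/c1cccc(F)c1`: 19500 nM
- compound 3, `O=C(CSc1nnc(-c2ccncc2)o1)N/N=C/c1cc(Br)ccc1O`: 6490 nM

In a functional assay on HepG2 cells (Homo sapiens) for cytotoxicity, read by MTT assay, with a stated time of 48 h (on this read-out higher numbers stand for weaker inhibition and lower numbers for stronger inhibition), compound 3 gives the lowest of the three numbers. The step from compound 1 to compound 3 was a 2.9-fold lower number from compound 1 to compound 3 (0.46 log units; beyond the scatter) and that from compound 2 to compound 3 was a 3.0-fold lower number from compound 2 to compound 3 (0.48 log units; beyond the scatter); compound 1 and compound 2 differ only by a 1.0-fold higher number from compound 1 to compound 2 (0.02 log units; within the scatter). Compound 4, `O=C(CSc1nnc(-c2ccncc2)o1)N/N=C/c1cc(Cl)cc(Cl)c1O`, keeps the shared core and the hydroxyphenyl arrangement of compound 3 and differs from it by 3,5-dichloro-2-hydroxyphenyl in place of 5-bromo-2-hydroxyphenyl on a carbon with a double bond to nitrogen. Within the data shown here, the two measured steps that lower the number both bring in the 5-bromo-2-hydroxyphenyl group in place of a halophenyl without a hydroxy group; compound 4 retains that hydroxy group, and no measured pair shows what exchanging the bromine for two chlorines does. The expectation is therefore a step of a 1.2-fold lower number from compound 3 to compound 4 (0.07 log units; within the scatter), no movement beyond the scatter. Compound 4 is estimated at 5500 nM in this assay, with a range from 2500 nM to 14000 nM.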

Compound 4, half-maximal inhibitory concentration: 3260 nM
Beside the measured number, compound 4's estimate is 1.7-fold (0.23 log units) above it; low and high end bracket the measured number.
By their numbers in this assay, from the lowest: compounds 4 and 3 (each within the scatter of the next); then compounds 1 and 2 (each within the scatter of the next).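

In this assay, placing 3,5-dichloro-2-hydroxyphenyl in place of 5-bromo-2-hydroxyphenyl on a carbon with a double bond to nitrogen gives a 2.0-fold lower number from compound 3 to compound 4 (0.30 log units; within the scatter), so exchanging the bromine for two chlorines at this position produces no change that can be told from the scatter. Against the groups without a hydroxy group, the same new group gives a 6.0-fold lower number from compound 2 to compound 4 (0.78 log units; beyond the scatter) and a 5.7-fold lower number from compound 1 to compound 4 (0.76 log units; beyond the scatter), so among these four compounds both hydroxyphenyl compounds stand apart from the two halophenyl compounds, and none goes against this. Nothing available accounts for these differences.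

The compounds shown do not separate the hydroxy group from the halogens, as each compound here with a hydroxy group also carries halogen on the same ring. As far as these compounds go, whether a methoxy group or an amine in place of that hydroxy group would keep the lower numbers remains open.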